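The compounds below may be only part of what the source reports. "The series", "measured", "known", "first", "only" and "open" are said of these compounds alone.

Compound 1 `Cc1cc(C)c(CN2CCc3ccc(O[C@@H]4CCOC4)c(Cl)c3C2=O)c(=O)[nH]1`: 21 mL.min-1.g-1
Compound 2 `COc1cccc(C(=O)NCc2c(C)cc(C)[nH]c2=O)c1Cl`: 8 mL.min-1.g-1
Compound 3 `Cc1cc(C)c(CN2CCc3ccc(OC(C)C)cc3C2=O)c(=O)[nH]1`: 19 mL.min-1.g-1

All three numbers come from an ADME assay on liver (Homo sapiens) for metabolic stability, read by LC-MS, using microsomes and NADPH, with a stated time of 45 min, tested at 1 uM; on this read-out lower numbers stand for slow clearance and higher numbers for fast clearance. On this read-out, compound 3 gives 19 mL.min-1.g-1, the second highest of the three. Within the data shown here, that value lies within the usual scatter of the one for compound 1, so these two cannot be told apart. Compound 2, at 8 mL.min-1.g-1, is lower than compound 3 by more than the scatter.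

The next compound is compound 4 `Cc1cc(C)c(CN2CCc3ccc(OC(C)C)c(Cl)c3C2=O)c(=O)[nH]1`. It differs from compound 3 by one change: chloro in place of hydrogen on an aromatic carbon. The chloro replaces a hydrogen on an aromatic carbon, ortho to an isopropoxy group.

Among the measured compounds shown here, no measured pair shows this change on its own, so the evidence is indirect. Compound 1 carries a chloro on its core alongside a different ether group and gives 21 mL.min-1.g-1, which suggests that a chloro on this core can go with a number near that of compound 3. Compound 2 also carries a chloro but gives 8 mL.min-1.g-1, on a different structure, so the hint is weak.

A small rise, within the scatter, is expected in this assay. The estimated step is a 1.3-fold higher number from compound 3 to compound 4 (0.10 log units; within the scatter). For compound 4 the estimate is 24 mL.min-1.g-1, with an expected range from 12 mL.min-1.g-1 to 48 mL.min-1.g-1.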

Compound 4, intrinsic clearance in microsomes in the Homo sapiens assay: 53 mL.min-1.g-1
For compound 4 the middle estimate is 2.2-fold (0.34 log units) below the measured one; the measured number lies above the stated range.
By their numbers in the Homo sapiens assay, from the lowest: compound 2; then compounds 3 and 1 (each within the scatter of the next); then compound 4.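

In the Homo sapiens assay, putting chloro in place of hydrogen on this aromatic carbon, ortho to an isopropoxy group, gives a 2.8-fold higher number from compound 3 to compound 4 (0.45 log units; beyond the scatter), so the weak earlier hint that a chloro on the shared core would leave the number close to that of compound 3 (19 mL.min-1.g-1) does not hold for this ether. The chloro alone does not set the number either: with it kept in place, isopropyl in place of oxolan-3-yl on the oxygen gives a 2.5-fold higher number from compound 1 to compound 4 (0.40 log units; beyond the scatter), which shows that the group on the oxygen also counts once the chloro is there. In a physicochemical assay for lipophilicity, at pH 7.4 (on this read-out lower numbers stand for lower lipophilicity and higher numbers for higher lipophilicity), the same chloro change shows only a number 0.20 log units higher from compound 3 to compound 4 (within the scatter), with compound 3 at 2.5 and compound 4 at 2.7 as the two values, and nothing given here explains the rise in clearance.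

It remains open whether the chloro step is as large with oxolan-3-yl on the oxygen, since the compounds shown give that ether only with the chloro present. Also open, on these data alone, is how a fluoro, a methyl or a nitrile on this same aromatic carbon would compare with hydrogen and chloro, and whether a longer chain on the oxygen would shift the number further.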